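Chalcone series: chloro for fluoro on the styryl ring

This account rests on a few compounds, and the source may have more. Where it says the series, first, only, none or still open, it means among the compounds named here.

Working notes. Compound 1 `O=C(/C=C/c1ccc(Cl)cc1)c1ccccc1` and compound 3 `O=C(/C=C/c1ccc(F)cc1)c1ccccc1` share one core; compound 2 `Cc1ccc(COc2ccc(C(=O)/C=C/c3ccc(F)cc3)cc2)cc1` and compound 4 `Cc1ccc(COc2ccc(C(=O)/C=C/c3ccc(Cl)cc3)cc2)cc1` share a second core. The difference between the two cores is not broken down here. In a functional assay on HCT-116 cells (Homo sapiens) for antiproliferative activity, read by sulforhodamine B assay, with a stated time of 3 days, tested at 25 uM (a lower number here means a weaker effect, a higher number a stronger effect of the compound at the concentration tested), compound 1 gives 97.5%, and compound 3 gives 86.8%. For compound 2 the result in this assay is "not determined" (no result reported), so no number exists for it. The step of a number 10.7 percentage points higher from compound 3 to compound 1 (beyond the scatter) belongs to the change (chloro in place of fluoro on an aromatic carbon). The same change, (chloro in place of fluoro on an aromatic carbon), leads from compound 2 to compound 4; both occurrences sit at the same kind of place, on an aromatic carbon of a six-membered aromatic ring of carbon only, para to a large group. Within the data shown here, with no value for compound 2, no step in this assay can be anchored for compound 4; the expectation rests only on compound 1 giving 97.5% with the same chloro group on the smaller core, while the second core is untested. In this assay compound 4 is expected to give about 85%, estimated between 45% and 100%.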

Compound 4, a percentage reported as inhibition, at one concentration (the size of the read-out at that concentration, not a potency): 12.3%
The estimate for compound 4 lay 72.7 percentage points above the measured number; measured number outside the range, below it.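

Among these compounds, no step from compound 2 to compound 4 can be read in this assay, as compound 2 has no number there. The compounds shown leave open whether chloro in place of fluoro on the core of compound 4 acts as in the step of a number 10.7 percentage points higher from compound 3 to compound 1 (beyond the scatter). Nothing at hand bears on the value of compound 4.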